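The source may hold more compounds than are shown below. What is called first, only, known or untested is meant among the compounds shown, and "the series" means these compounds.

Measured compounds:
Compound 1 `CC(C)(C)c1ccc(C(=O)NCc2ccc(-c3nnn[nH]3)cc2)cc1` — 120 nM
Compound 2 `CC(C)(C)c1ccc(C(=O)NCc2cccc(C(=O)O)c2)cc1` — 1700 nM

Two compounds share a core and differ only in the group at the far end. In an assay on HeLa cells with Bile acid receptor (Homo sapiens) as the target, read by a luciferase reporter, with a stated time of 24 h (on this read-out higher numbers stand for an effect only at larger amounts of compound and lower numbers for an effect already at smaller amounts), compound 1 gives 120 nM, the lowest of the two numbers. Compound 2, carrying a carboxylic acid in place of the 1H-tetrazol-5-yl, gives 1700 nM in this assay, a gap that lies beyond the usual scatter. Compound 3 `CCOc1ccc(CNC(=O)c2ccc(C(C)(C)C)cc2)cc1` has not yet been measured in this assay. It differs from compound 1 as follows: ethoxy in place of 1H-tetrazol-5-yl on an aromatic carbon. For the measured compounds named here, no measured pair shows this particular change, so the size of the step is unknown. Given that compound 2 already stands at 1700 nM once the 1H-tetrazol-5-yl is gone, compound 3 is expected to show a step of a 21-fold higher number from compound 1 to compound 3 (1.32 log units; beyond the scatter) towards a higher number. Compound 3 is therefore estimated at 2500 nM, with a range from 500 nM to 12000 nM.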

Compound 3, half-maximal effective concentration: 160 nM
The estimate for compound 3 lay 16-fold (1.19 log units) above the measured number, outside the stated range (below it).
By their numbers in this assay, from the lowest: compounds 1 and 3 (each within the scatter of the next); then compound 2.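

In this assay, ethoxy in place of 1H-tetrazol-5-yl on an aromatic carbon, para to a large group, gives a 1.3-fold higher number from compound 1 to compound 3 (0.12 log units; within the scatter). At this position, then, a group with no ring, no hydrogen-bond donor and fewer heavy atoms stands within the scatter of the 1H-tetrazol-5-yl, so for this pair the five-membered aromatic ring with 4 hetero atoms is not required for a number of this size. Nothing at hand explains this result.

The compounds shown leave open how an amine, a longer alkoxy chain or a propyl group, with carbon in place of the oxygen of ethoxy, would read at this place. They also leave open whether this exchange would give a similar step on any core other than that of compound 1.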